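The source may hold more compounds than are shown below. What is called first, only, known or untested is meant among the compounds shown, and "the series" means these compounds.

In an ADME assay on the whole organism with Oryza sativa as the target, tested at 10 uM (on this read-out higher numbers stand for a weaker effect at the one concentration tested and lower numbers for a stronger effect), compound 1 `C[C@@H](NC(=O)Nc1ccccc1F)c1ccccc1` gives 77%, the lowest of the two numbers in hand. Among the compounds with values here, compound 2 `C[C@@H](NC(=O)Nc1ccc(F)cc1F)c1ccccc1` gives 93%, and the step of a number 16 percentage points higher from compound 1 to compound 2 (beyond the scatter) is the only measured change of the same kind, fluoro in place of hydrogen on an aromatic carbon. Compound 3 `C[C@@H](NC(=O)Nc1cc(F)ccc1F)c1ccccc1` differs from compound 1 by fluoro in place of hydrogen on an aromatic carbon. The measured step from compound 1 to compound 2 points to a rise for compound 3 as well, though the fluoro enters at another place, so the size is uncertain. For compound 3 the expected step is a number 11 percentage points higher from compound 1 to compound 3 (beyond the scatter), giving an estimate of 88% with a range from 74% to 98%.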

Compound 3, a percentage reported as activity, at one concentration (the size of the read-out at that concentration, not a potency): 92%
Compound 3: middle estimate off by 4 percentage points, on the low side, and the stated range covers the measured number.
By their numbers in this assay, from the lowest: compound 1; then compounds 3 and 2 (each within the scatter of the next).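

In this assay, fluoro on the aromatic carbon para to a fluoro group and meta to a large group gives a number 15 percentage points higher from compound 1 to compound 3 (beyond the scatter), so a rise beyond the scatter is now seen at a second place on this ring. Compound 2 at 93% and compound 3 at 92% lie within the scatter of each other, so these two fluoro placements are not told apart. Nothing measured on these compounds explains the rise.

Still open, going by these compounds, is whether chloro, methoxy or an amine at this place would give a similar number.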